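Cyanophenyl for nitrophenyl in a series without clear steps

This account rests on a few compounds, and the source may have more. Where it says the series, first, only, none or still open, it means among the compounds named here.

Among the compounds with values here, in a functional assay on DU-145 cells (Homo sapiens) for antiproliferative activity, read by CCK-8 assay, with a stated time of 72 h (on this read-out lower numbers stand for stronger inhibition and higher numbers for weaker inhibition), three compounds built on one shared core have numbers so far. Compound 1 `Cc1cc(Nc2cc(N3CCN(C)CC3)nc(Nc3ccc(S(N)(=O)=O)cc3)n2)n[nH]1` gives 926 nM. Compound 2 `Cc1cc(Nc2cc(N3CCN(C)CC3)nc(Nc3ccc([N+](=O)[O-])cc3)n2)n[nH]1` gives 1200 nM. Compound 3 `Cc1cc(Nc2cc(N3CCN(C)CC3)nc(Nc3cccc([N+](=O)[O-])c3)n2)n[nH]1` gives 1340 nM, which places it within the scatter of both others, as the comparisons show: a 1.4-fold higher number from compound 1 to compound 3 (0.16 log units; within the scatter) and a 1.1-fold higher number from compound 2 to compound 3 (0.05 log units; within the scatter).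

Compound 4 `Cc1cc(Nc2cc(N3CCN(C)CC3)nc(Nc3ccc(C#N)cc3)n2)n[nH]1` has not yet been measured. It differs from compound 3 in a single place: 4-cyanophenyl in place of 3-nitrophenyl on a nitrogen on an aromatic ring. In words, this is 4-cyanophenyl in place of 3-nitrophenyl on a nitrogen on an aromatic ring.

Within the data shown here, two measured steps bear most directly on this change. The exchange of 4-nitrophenyl for 3-nitrophenyl amounts to a 1.1-fold higher number from compound 2 to compound 3 (0.05 log units; within the scatter), and nitro in place of sulfamoyl amounts to a 1.3-fold higher number from compound 1 to compound 2 (0.11 log units; within the scatter). Both lie within the scatter, and so far no change at this part of the molecule has moved the number beyond it. Among the measured compounds shown here, no compound with a nitrile has yet been measured, so this expectation remains an extrapolation and the range is kept wide.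

No step beyond the scatter is expected, and the estimated step is a 1.2-fold lower number from compound 3 to compound 4 (0.09 log units; within the scatter). For compound 4 the expected value is 1100 nM, with an estimated range from 500 nM to 2500 nM.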

Compound 4, half-maximal inhibitory concentration: 1270 nM
Compound 4: the middle estimate sits 1.2-fold (0.06 log units) below what was measured; low and high end bracket the measured number.
By their numbers in this assay, from the lowest: compounds 1, 2, 4 and 3 (each within the scatter of the next).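

With the nitrile, a third kind of group on this phenyl ring joins sulfamoyl and nitro, and in this assay it separates from neither of them: cyano in place of nitro gives a small step (a 1.1-fold higher number from compound 2 to compound 4 (0.02 log units; within the scatter)), and cyano in place of sulfamoyl stays just as unresolved (a 1.4-fold higher number from compound 1 to compound 4 (0.14 log units; within the scatter)). The exchange that also alters where the group sits, 4-cyanophenyl in place of 3-nitrophenyl, likewise stays unresolved (a 1.1-fold lower number from compound 3 to compound 4 (0.02 log units; within the scatter)), so among these four compounds no change in this group leaves the scatter and none goes against that pattern. The data offer no measurement that would explain why these groups cannot be told apart.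

The compounds shown leave open whether any group at this place can move the number beyond the scatter, for example an amine, a carboxylic acid or a longer chain on the phenyl ring. They also leave open whether 3-cyanophenyl would match 4-cyanophenyl, and whether changes elsewhere on the shared core matter more than changes here.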